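The compounds below may be only part of what the source reports. "The series", "measured", "known", "first", "only" and "open" are said of these compounds alone.

Working notes on the series. Going by the values given here, compound 1 `CCOc1cc(NC(=O)CCCCCC(=O)Nc2cc(-c3ccccc3)ccc2N)cc2c1OCC([N+](=O)[O-])=C2` gives 28% in an assay on isolated protein for inhibition of protein deacetylase HDAC6 (Homo sapiens), read by fluorescence, with stated times of 10 min and 30 min, tested at 10 uM (a lower number here means less inhibition, a higher number more inhibition at the concentration tested (going by the name of the read-out)), the highest of the three numbers so far. Compound 2 `CCOc1cc(NC(=O)CCCCCCC(=O)Nc2cc(-c3ccc(C)s3)ccc2N)cc2c1OCC([N+](=O)[O-])=C2` gives 19% in this assay, which lies within the usual scatter of compound 1, so no order between the two can be read. Compound 3 `CCOc1cc(NC(=O)CCCCC(=O)Nc2cc(-c3ccc(C)s3)ccc2N)cc2c1OCC([N+](=O)[O-])=C2` gives 8% in this assay, a number beyond the scatter below compound 1. No pair among these three differs in a single place, so no clean step is available.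

Compound 4 `CCOc1cc(NC(=O)CCCCCC(=O)Nc2cc(-c3ccc(C)s3)ccc2N)cc2c1OCC([N+](=O)[O-])=C2` is the next candidate and differs from compound 1 by 5-methylthiophen-2-yl in place of phenyl on an aromatic carbon. The 5-methylthiophen-2-yl group that enters is also present in compound 2 and compound 3, whose values in this assay both sit under that of compound 1, though only compound 3 does so beyond the scatter. The expected step from compound 1 to compound 4 in this assay is therefore a small decrease, a number 10 percentage points lower from compound 1 to compound 4 (within the scatter), possibly not beyond the scatter. Compound 4 is expected to give about 18% in this assay, estimated between 6% and 30%, because compound 2 gives 19% and compound 3 gives 8%.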

Compound 4, a percentage reported as inhibition, at one concentration (the size of the read-out at that concentration, not a potency): 36%
Compound 4: the middle estimate sits 18 percentage points below what was measured; measured number outside the range, above it.
By their numbers in this assay, from the lowest: compound 3; then compounds 2, 1 and 4 (each within the scatter of the next, the first and the last beyond it).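

In this assay, going by these compounds alone, 5-methylthiophen-2-yl in place of phenyl on this aromatic carbon, para to an amino group, gives a number 8 percentage points higher from compound 1 to compound 4 (within the scatter) and is the first single-place change. At this position, therefore, a five-membered aromatic ring with 1 hetero atom and a six-membered aromatic ring of carbon only cannot be told apart in this read-out, at least on the chain shared by compound 1 and compound 4. The earlier compounds could not show this, since no pair among them differed in one place only, and nothing measured on these compounds offers a reason for the step.

Still open, from the compounds shown here alone, is whether a different kind of group on this carbon, such as a pyridine ring, an amine or a carboxylic acid, would move the number beyond the scatter, as neither ring tested here does so relative to the other. Also open, going by these compounds, is whether these readings at a single concentration would hold as a potency order, and whether phenyl on a shorter or longer chain would track the values of the 5-methylthiophen-2-yl compounds.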